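Fluoro added to the aryl ring of compound 3

A few compounds are considered here, and "the series" means these few. Any claim that something is new, unique, unknown or untested is made for them only; others in the source may bear on it.

Working notes on the series. Three compounds have numbers in a functional assay on CHO cells for agonist activity at metabotropic glutamate receptor 2 (Homo sapiens), read by scintillation counting and GTPgammaS binding, with a stated time of 30 min; on this read-out higher numbers stand for an effect only at larger amounts of compound and lower numbers for an effect already at smaller amounts. Compound 1 `COc1c(F)cccc1C1CCN(c2ccn3c(CC(F)(F)F)nnc3c2C#N)CC1` gives 31 nM. Compound 2 `COc1ccc(F)cc1C1CCN(c2ccn3c(CC(F)(F)F)nnc3c2Cl)CC1` gives 10.5 nM. Compound 3 `COc1cccc(F)c1C1CCN(c2ccn3c(CC4CC4)nnc3c2Cl)CC1` gives 6 nM, which sits at the low end of the numbers shown; the number of compound 2 lies within the scatter of it, while the number of compound 1 lies beyond the scatter. Among the measured compounds shown here, the three differ in several places at once, so no single step between measured compounds can be read from them.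

Compound 4 `COc1ccc(F)c(F)c1C1CCN(c2ccn3c(CC4CC4)nnc3c2Cl)CC1` has not been measured. It differs from compound 3 by fluoro in place of hydrogen on an aromatic carbon. For the measured compounds named here, nothing among the measured compounds isolates this change, so there is no step to lean on. The expectation is a step of a 1.2-fold higher number from compound 3 to compound 4 (0.07 log units; within the scatter), small enough to fall within the scatter and without a settled direction. For compound 4 the estimate in this assay is 7 nM, with a range from 2.5 nM to 20 nM.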

Compound 4, half-maximal effective concentration: 9.3 nM
For compound 4 the middle estimate is 1.3-fold (0.12 log units) below the measured one; low and high end bracket the measured number.
By their numbers in this assay, from the lowest: compounds 3, 4 and 2 (each within the scatter of the next); then compound 1.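

In this assay, among the compounds shown here, fluoro in place of hydrogen on this aromatic carbon gives a 1.6-fold higher number from compound 3 to compound 4 (0.19 log units; within the scatter), which is the first step that isolates a change in one place. The carbon in question is ortho to a fluoro group, meta to a large group and para to a methoxy group, and going from the 2-fluoro-6-methoxyphenyl group to the 2,3-difluoro-6-methoxyphenyl group at this site produces no difference that can be told apart from the scatter of repeated measurements, so this position tolerates a fluoro on this read-out. No data accompany the result that could say why the step is this small.

The compounds shown leave open whether this carbon takes anything other than fluoro, such as a chloro group, an amine or a carboxylic acid, and whether those would also stay within the scatter. They also leave open whether the same fluoro gives a similar step when the cyclopropylmethyl group shared by compound 3 and compound 4 is replaced by the 2,2,2-trifluoroethyl group of compound 2.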